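A few compounds are considered here, and "the series" means these few. Any claim that something is new, unique, unknown or untested is made for them only; others in the source may bear on it.

In a functional assay on HT-29 cells (Homo sapiens) for inhibition, read by sulforhodamine B assay, with a stated time of 48 h (on this read-out lower numbers stand for stronger inhibition of growth and higher numbers for weaker inhibition of growth), compound 1 (`COc1cccc(C(=O)NNC(=O)c2ccc3[nH]c(-c4ccc([N+](=O)[O-])o4)nc3c2)c1`) gives 31.3 ug/mL and compound 2 (`O=C(NNC(=O)c1cc2ccccc2cc1O)c1ccc2[nH]c(-c3ccc([N+](=O)[O-])s3)nc2c1`) gives 62.5 ug/mL, two values within the usual scatter of each other. Compound 3 (`COc1cccc(C(=O)NNC(=O)c2ccc3[nH]c(-c4ccc([N+](=O)[O-])s4)nc3c2)c1`) differs from compound 2 in one place, with 3-methoxyphenyl in place of 3-hydroxynaphthalen-2-yl on a carbonyl carbon. Compound 1 also carries 3-methoxyphenyl and gives 31.3 ug/mL, so a small step toward a lower number in this assay, none beyond the scatter, is expected. The estimated change is a 1.6-fold lower number from compound 2 to compound 3 (0.19 log units; within the scatter). Compound 3 is expected at 40 ug/mL, with an estimated range of 15 ug/mL to 100 ug/mL.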

Compound 3, concentration for 50% growth inhibition: 31.3 ug/mL
Compound 3: the middle estimate sits 1.3-fold (0.11 log units) above what was measured; the range from low to high includes it.
By their numbers in this assay, from the lowest: compounds 1, 3 and 2 (each within the scatter of the next).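

Among these compounds, on the carbonyl carbon, 3-methoxyphenyl in place of 3-hydroxynaphthalen-2-yl gives a 2.0-fold lower number from compound 2 to compound 3 (0.30 log units; within the scatter) in this assay, the first direct reading of this change. On the aromatic carbon, 5-nitrothiophen-2-yl in place of 5-nitrofuran-2-yl gives no change at the digits printed from compound 1 to compound 3 (within the scatter), so neither single change moves the read-out beyond the scatter. Nothing available explains these values. The compounds shown leave open what a carboxylic acid or a dimethylamino group on the phenyl ring would do. They also leave open how a compound lacking the nitro group on the thiophene would read.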